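This account rests on a few compounds, and the source may have more. Where it says the series, first, only, none or still open, it means among the compounds named here.

Measured in a functional assay on PC-3 cells (Mus musculus) for cytotoxicity against PC-3 (Homo sapiens); a higher number here means a weaker inhibitor, a lower number a stronger inhibitor:
- compound 1 `CCCN(CCC)c1c([N+](=O)[O-])cc(S(=O)(=O)Nc2cccc(C)c2)cc1[N+](=O)[O-]`: 25000 nM
- compound 2 `CCCN(CCC)c1c([N+](=O)[O-])cc(S(=O)(=O)Nc2cccc(Cl)c2)cc1[N+](=O)[O-]`: 18000 nM
- compound 3 `CCCN(CCC)c1c([N+](=O)[O-])cc(S(=O)(=O)Nc2cc(Cl)cc(Cl)c2)cc1[N+](=O)[O-]`: 11000 nM

Compound 3, at 11000 nM, sits within the scatter of compound 2, and only a 2.3-fold lower number from compound 1 to compound 3 (0.36 log units; beyond the scatter) clears the scatter. Compound 4 `CCCN(CCC)c1c([N+](=O)[O-])cc(S(=O)(=O)N(C)c2ccccc2)cc1[N+](=O)[O-]` has methyl(phenyl)amino in place of (3,5-dichlorophenyl)amino on a sulfonyl sulfur. The best guides are that same step and a 1.6-fold lower number from compound 2 to compound 3 (0.21 log units; within the scatter). Both are small, and compound 4 carries no chlorine. Among the compounds with values here, no measured compound carries methyl(phenyl)amino, so that part of the change remains unknown. A modest rise in this assay is therefore expected, back towards compound 1 at 25000 nM. The expected change is a 2.3-fold higher number from compound 3 to compound 4 (0.36 log units; beyond the scatter). For compound 4 the estimated value is 25000 nM, with an expected range of 10000 nM to 60000 nM.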

Compound 4, half-maximal inhibitory concentration: > 100000 nM
Compound 4 was reported as a limit; the forecaster's own chance of this, stated with the estimate: 15%; middle value at least 4.0-fold (0.60 log units) away from the limit.
By their numbers in this assay, from the lowest: compounds 3, 2 and 1 (each within the scatter of the next, the first and the last beyond it). At a limit, above all of these: compound 4.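

Compound 4 is reported only as a limit in this assay: the limit of > 100000 nM in this assay, at which 1 of the 4 values shown sits. Within the data shown here, replacing the group on the sulfonyl sulfur with methyl(phenyl)amino gives an at least 9.0-fold higher number from compound 3 to compound 4 (0.95 log units; beyond the scatter) and an at least 5.5-fold higher number from compound 2 to compound 4 (0.74 log units; beyond the scatter) and an at least 4.0-fold higher number from compound 1 to compound 4 (0.60 log units; beyond the scatter) as larger shifts than any step among the earlier compounds. This position therefore responds far more to this change than to swapping ring substituents, and the entering group has no hydrogen-bond donor, unlike those it replaces. The loss of that donor and the loss of the ring substituent happen together here, so their contributions cannot be separated. Plain phenylamino and methyl(3,5-dichlorophenyl)amino remain open as the groups that would tell them apart.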